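Removing the acetyl group from compound 3

A few compounds are considered here, and "the series" means these few. Any claim that something is new, unique, unknown or untested is made for them only; others in the source may bear on it.

In an ADME assay on THP-1 cells (Homo sapiens) for cytotoxicity, read by flow cytometry and propidium iodide staining, with a stated time of 72 h (on this read-out higher numbers stand for weaker inhibition and lower numbers for stronger inhibition), compound 1 `CC(=O)Nc1ccc2oc(-c3ccccc3)cc(=O)c2c1` gives 97000 nM as its reading, and compound 3 `CC(=O)Nc1ccc2oc(-c3cccc(C(F)(F)F)c3)cc(=O)c2c1`, which carries a trifluoromethyl group on the same shared core, gives 50000 nM as its reading. For compound 2 `CC(=O)Nc1ccc2oc(-c3cccc(F)c3)cc(=O)c2c1` the reading > 125000 nM is a limit and not a number. Compound 3 lies within the scatter of compound 1, as a 1.9-fold lower number from compound 1 to compound 3 (0.29 log units; within the scatter) shows, while an at least 2.5-fold lower number from compound 2 to compound 3 (0.39 log units; beyond the scatter) sets it apart from that limit.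

Going by the values given here, compound 4 `Nc1ccc2oc(-c3cccc(C(F)(F)F)c3)cc(=O)c2c1` keeps the trifluoromethyl group, and hydrogen in place of acetyl on a nitrogen on an aromatic ring marks the one change: acetamido to amino. Each measured step, including an at least 1.2-fold higher number from compound 1 to compound 2 (0.11 log units; that floor lies within the scatter) as well, alters a group on an aromatic carbon, and none touches the acetamido group. They therefore give no direction for this change. Starting from compound 3 at 50000 nM as the anchor, the expected result is a 1.3-fold lower number from compound 3 to compound 4 (0.10 log units; within the scatter) and so no clear step in this assay beyond the scatter. The estimated value for compound 4 is 40000 nM in an expected range from 12000 nM to 125000 nM for this measurement.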

Compound 4, half-maximal inhibitory concentration: 34000 nM
Compound 4: the middle estimate sits 1.2-fold (0.07 log units) above what was measured, within the range that was stated.
By their numbers in this assay, from the lowest: compounds 4, 3 and 1 (each within the scatter of the next, the first and the last beyond it). At a limit, above all of these: compound 2.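

Going by these compounds alone, the acetamido group, which no earlier step touched, has now been changed, and in this assay replacing acetyl with hydrogen on the nitrogen gives a 1.5-fold lower number from compound 3 to compound 4 (0.17 log units; within the scatter). This is a step within the usual scatter, so the two readings cannot be told apart. With the trifluoromethyl group in place, the acetyl group is therefore not needed for a reading of this size, and the free amino group serves equally well in this assay.

Going by these compounds, this holds for a single pair, so it remains open whether the same swap would read alike with the fluoro group of compound 2 or the unsubstituted ring of compound 1, or whether a longer acyl chain or a methyl group on this nitrogen would shift the reading. Nothing among the data shown bears on the cause of this result.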